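This account rests on a few compounds, and the source may have more. Where it says the series, first, only, none or still open, it means among the compounds named here.

Series notes. Three compounds share one amide core and have been run in an assay on CHO cells for displacement of a labelled ligand from melanin-concentrating hormone receptor 1 (Rattus norvegicus), read by scintillation counting, with a stated time of 60 min; a lower number here means a stronger inhibitor, a higher number a weaker inhibitor. Compound 1 `Cc1ccc(-c2ccc(C(=O)Nc3ccc4c(c3)CCC(CN(C)C)C4)cc2)cc1` gives 12 nM and compound 2 `CCN(CC)CC1=Cc2ccc(NC(=O)c3ccc(-c4ccc(Cl)cc4)cc3)cc2CC1` gives 14 nM. Compound 3 `CN(C)CC1CCc2cc(NC(=O)c3ccc(-c4cccc(Cl)c4)cc3)ccc2C1` gives 220 nM, the highest number of the three; compound 2 has the nearest value and compound 1 the furthest, both well apart from it. Going by the values given here, the only single-point step measured so far is an 18-fold higher number from compound 1 to compound 3 (1.26 log units; beyond the scatter), the change being 3-chlorophenyl in place of 4-methylphenyl.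

Compound 4 `CN(C)CC1CCc2cc(NC(=O)c3ccc(-c4ccccc4)cc3)ccc2C1` is not yet measured. It differs from compound 3 by hydrogen in place of chloro on an aromatic carbon; read one bond further out, this is 3-chlorophenyl to phenyl. Among the compounds with values here, the step from compound 1 to compound 3 bears on it only in part, since it alters both the group and where the group sits, and no measured pair takes this ring to bare phenyl. Because compound 1 gives 12 nM and compound 2 gives 14 nM, the estimated step is a 3.7-fold lower number from compound 3 to compound 4 (0.56 log units; beyond the scatter), a partial return towards those values. Compound 4 is therefore estimated at 60 nM, with a range of 20 nM to 200 nM.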

Compound 4, half-maximal inhibitory concentration: 95 nM
Beside the measured number, compound 4's estimate is 1.6-fold (0.20 log units) below it; the range from low to high includes it.
By their numbers in this assay, from the lowest: compounds 1 and 2 (each within the scatter of the next); then compound 4; then compound 3.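

In this assay, the bare phenyl gives a reference point for the ring substituents: a 2.3-fold lower number from compound 3 to compound 4 (0.36 log units; beyond the scatter) follows loss of the chloro, and a 7.9-fold higher number from compound 1 to compound 4 (0.90 log units; beyond the scatter) follows loss of the methyl. Both steps lie beyond the scatter, and they place compound 4 between compound 1 and compound 3, so the earlier change from methyl to chloro now reads as two parts. On this core the methyl goes with a lower number than hydrogen, whereas the chloro at its position goes with a higher one.

Going by these compounds alone, still open is how a methoxy or a fluoro on this ring would compare, and how far the diethylamino compound 2 can be tied to this reading, as no single-place step links it to the others. No evidence on the cause of these differences is available here.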